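The source may hold more compounds than are shown below. What is called first, only, known or untested is meant among the compounds shown, and "the series" means these compounds.

In an ADME assay on L02 cells (Homo sapiens) for inhibition, read by CCK-8 assay, with a stated time of 48 h (a higher number here means a weaker inhibitor of growth, a lower number a stronger inhibitor of growth), three compounds have been measured so far. Compound 1 (`Cc1ccccc1Nc1nc(Nc2ccc(N3CCN(C(=O)OC(C)(C)C)CC3)cc2)ncc1Cl`) gives 1750 nM, compound 2 (`CN1CCN(c2ccc(Nc3ncc(Cl)c(Nc4ccccc4)n3)nc2)CC1`) gives 7990 nM, and compound 3 (`CN1CCN(c2ccc(Nc3ncc(Cl)c(NCc4ccc(C(F)(F)F)cc4)n3)nc2)CC1`) gives 26200 nM. Compound 3 thus has the highest number of the three, and it is the weakest inhibitor of growth among them.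

Compound 4 (`CN1CCN(c2ccc(Nc3ncc(Cl)c(NCc4ccco4)n3)nc2)CC1`) departs from compound 3 in one place: furan-2-yl in place of 4-(trifluoromethyl)phenyl on a saturated chain carbon bound to a nitrogen on an aromatic ring. In words, furan-2-yl stands in place of 4-(trifluoromethyl)phenyl on a saturated chain carbon bound to a nitrogen on an aromatic ring.

Going by the values given here, only one measured step bears on this change. It is a 3.3-fold higher number from compound 2 to compound 3 (0.52 log units; beyond the scatter), modest in size and beyond the scatter, with 4-(trifluoromethyl)benzyl in place of phenyl on a nitrogen on an aromatic ring. Among the compounds with values here, no measured compound carries furan-2-yl, so that step offers only a rough guide. Within the data shown here, removing the 4-(trifluoromethyl)phenyl might partly reverse it, so a small move toward a lower number is expected, no larger than that step and possibly within the scatter. The expected change is a 1.7-fold lower number from compound 3 to compound 4 (0.24 log units; within the scatter). For compound 4 the estimate in this assay is 15000 nM, with an expected range from 6500 nM to 32000 nM.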

Compound 4, concentration for 50% growth inhibition: 45700 nM
Compound 4: middle estimate off by 3.0-fold (0.48 log units), on the low side; the measured number lies above the stated range.
By their numbers in this assay, from the lowest: compound 1; then compound 2; then compounds 3 and 4 (each within the scatter of the next).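

In this assay, exchanging 4-(trifluoromethyl)phenyl for furan-2-yl on the saturated chain carbon gives a 1.7-fold higher number from compound 3 to compound 4 (0.24 log units; within the scatter), so this assay does not separate the two groups at this place, although they differ in ring size, in heavy atoms and in the hydrogen-bond acceptor that furan-2-yl brings. The phenyl on the nitrogen in compound 2 now stands apart from two different groups carried on a chain carbon: in addition to a 3.3-fold higher number from compound 2 to compound 3 (0.52 log units; beyond the scatter) there is a 5.7-fold higher number from compound 2 to compound 4 (0.76 log units; beyond the scatter), so among these compounds the earlier step is not tied to the 4-(trifluoromethyl)phenyl. No measurement given here explains the size of either step.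

The compounds shown leave open whether the chain carbon itself accounts for these steps, a question that an unsubstituted benzyl on the same nitrogen would put directly against compound 2. They also leave open whether a group with no aromatic ring at this place, such as cyclohexyl or an amine on a longer chain, would read with compound 2 or with compound 3 and compound 4.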